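Removing One Chloro Group from a Dichloropurine Core

The compounds below may be only part of what the source reports. "The series", "measured", "known", "first", "only" and "open" are said of these compounds alone.

Of the compounds shown here, two have been tested in a functional assay on A549 cells (Homo sapiens) for cytotoxicity, read by sulforhodamine B assay, with a stated time of 48 h; on this read-out lower numbers stand for stronger inhibition of growth and higher numbers for weaker inhibition of growth. Compound 1 `Nc1nc(Cl)c2ncn(Cc3ccccc3CCl)c2n1` gives 21900 nM there, and compound 2 `ClCc1cccc(Cn2cnc3nc(Cl)nc(Cl)c32)c1` gives 12000 nM, the lowest of the two numbers, although the gap to compound 1 lies within the usual scatter. Compound 3 `ClCc1cccc(Cn2cnc3ncnc(Cl)c32)c1` is derived from compound 2 by a single change, (hydrogen in place of chloro on an aromatic carbon). Among the measured compounds shown here, no measured pair shows what this change does, so the expected step of a 1.8-fold higher number from compound 2 to compound 3 (0.26 log units; within the scatter) is an informed guess leaning toward somewhat weaker growth inhibition. Compound 3 is therefore expected to give about 22000 nM, within a range from 7000 nM to 70000 nM.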

Compound 3, concentration for 50% growth inhibition: 17400 nM
Estimate against measurement, compound 3: 1.3-fold (0.10 log units) above; the range from low to high includes it.
By their numbers in this assay, from the lowest: compounds 2, 3 and 1 (each within the scatter of the next).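

Hydrogen in place of chloro on this aromatic carbon, between two ring nitrogen atoms, gives a 1.5-fold higher number from compound 2 to compound 3 (0.16 log units; within the scatter) in this assay, the first measured reading of this swap. The values of compound 2 and compound 3 cannot be told apart, so growth inhibition in this assay does not depend measurably on having chloro at this position. Nothing measured here offers an explanation for this result. Open, on these data alone, is how a methoxy group or a carboxylic acid on this same carbon would read.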